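From 3-methylphenyl to 3-ethylphenyl in a cell assay

The source may hold more compounds than are shown below. What is called first, only, known or untested is meant among the compounds shown, and "the series" means these compounds.

Two compounds with a shared core have numbers in a functional assay on CHO-TAX 5-6 cells (Cricetulus griseus) for antiproliferative activity, read by sulforhodamine B assay, with a stated time of 48 h (on this read-out lower numbers stand for stronger inhibition and higher numbers for weaker inhibition), so far. There compound 1 (`O=C1NCCN1c1ccc(S(=O)(=O)Nc2ccc3[nH]ccc3c2)cc1`) gives 640 nM and compound 2 (`Cc1cccc(NS(=O)(=O)c2ccc(N3CCNC3=O)cc2)c1`) gives 150 nM as its reading. Compound 2 thus holds the lower of the two numbers, and its gap to compound 1 lies beyond the usual scatter. Compound 3 (`CCc1cccc(NS(=O)(=O)c2ccc(N3CCNC3=O)cc2)c1`) has yet to be measured. It differs from compound 2 by a single change (methyl in place of hydrogen on a saturated chain carbon bound to an aromatic carbon): methyl in place of hydrogen on a saturated chain carbon bound to an aromatic carbon, which turns 3-methylphenyl into 3-ethylphenyl. Within the data shown here, no measured pair shows this change, so the expectation in this assay is cautious: no shift beyond the scatter, in either direction. The expected step of a 1.1-fold higher number from compound 2 to compound 3 (0.03 log units; within the scatter) is therefore small. For compound 3 the estimate is 160 nM, with the measurement expected between 50 nM and 500 nM once it is made.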

Compound 3, half-maximal inhibitory concentration: 140 nM
Beside the measured number, compound 3's estimate is 1.1-fold (0.06 log units) above it; the measured number falls inside the stated range.
By their numbers in this assay, from the lowest: compounds 3 and 2 (each within the scatter of the next); then compound 1.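

In this assay methyl in place of hydrogen on a saturated chain carbon bound to an aromatic carbon, which turns 3-methylphenyl into 3-ethylphenyl, gives a 1.1-fold lower number from compound 2 to compound 3 (0.03 log units; within the scatter) and so no shift beyond the scatter. Among these compounds, this is the first pair here that differs in one place, and it shows that this position accepts the added carbon with the number unmoved, at least for this one step. No supporting measurement bears on why the two compounds read alike.

From the compounds shown here alone, whether the number would also hold with a longer chain such as propyl, a branched one such as isopropyl, or an amine or a carboxylic acid at the end of the chain remains open. So does whether the same change would read alike on a different core.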